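An Aromatic Group Exchange on a Carbonyl Carbon

A few compounds are considered here, and "the series" means these few. Any claim that something is new, unique, unknown or untested is made for them only; others in the source may bear on it.

In an ADME assay on microsomes from liver (Mus musculus) for metabolic stability, read by LC-MS, with a stated time of 30 min, tested at 1 uM (on this read-out lower numbers stand for a less stable compound and higher numbers for a more stable compound), compound 1 `O=C(NCc1ccc(S(=O)(=O)N2CCCCC2)cc1)c1cc2ccncc2[nH]1` gives "below limit of detection" (no number reported). That result is a limit of the assay and not a number, so compound 1 has no single value to start from. Going by the values given here, compound 2 `Cn1c(C(=O)NCc2ccc(S(=O)(=O)c3ccccc3)cc2)cc2cnccc21`, the only other compound tested so far, gives 34%. Among the compounds with values here, it does not differ from compound 1 in one place alone, so it offers no measured step to draw on. Compound 3 `O=C(NCc1ccc(S(=O)(=O)N2CCCCC2)cc1)c1cc2cccnc2s1` keeps the rest of compound 1 and changes one group on a carbonyl carbon: a group of 9 heavy atoms (7 carbon, 1 nitrogen, 1 sulfur; one five-membered aromatic ring with 1 hetero atom, one six-membered aromatic ring with 1 hetero atom) in place of a group of 9 heavy atoms (7 carbon, 2 nitrogen; one five-membered aromatic ring with 1 hetero atom, one six-membered aromatic ring with 1 hetero atom), on a carbonyl carbon. Within the data shown here, with no measured step to guide it, the expectation in this assay is a modest rise from compound 1, with more compound remaining, though a further limit is quite possible. For compound 3 the estimated value is 15%, with an expected range of 2% to 40%.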

Compound 3, percent of the compound remaining: "below limit of detection" (no number reported)
Nothing numeric was reported for compound 3, and the estimate cannot be compared.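

In this assay compound 1 and compound 3 each give only a limit of the assay and not a number, so no step can be read between them. No measured evidence bears on this result. The compounds shown leave open how the group exchange on the carbonyl carbon changes the percent of compound remaining.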